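The source may hold more compounds than are shown below. What is called first, only, known or untested is meant among the compounds shown, and "the series" means these compounds.

Measured compounds:
- compound 1, `Cc1ccn2nc(C)c(C(=O)NCc3ccc(N4CCN(c5ccc(F)cc5)CC4)cc3)c2c1`: in an ADME assay on Vero cells (Chlorocebus sabaeus) for cytotoxicity, read by CCK-8 assay, with a stated time of 72 h (a higher number here means a weaker inhibitor, a lower number a stronger inhibitor), compound 1 gives > 100000 nM, a limit rather than a number.
- compound 2, `Cc1ccc2c(C(=O)NCc3ccc(N4CCC(c5ccc(OC(F)(F)F)cc5)CC4)cc3)c(C)nn2c1`: in this assay compound 2 gives > 100000 nM, likewise a limit rather than a number.

Among the measured compounds shown here, compound 2 stands at a limit only: no number is known for it, and the one other value shown, that of compound 1, is also a limit. That is the whole picture so far: the limit of > 100000 nM in this assay, at which 2 of the 2 values shown sit. For the measured compounds named here, no step between measured compounds can be worked out here, since compound 1 and compound 2 differ in more than one place.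

Compound 3, `Cc1nn2ccccc2c1C(=O)NCc1ccc(N2CCC(c3ccc(OC(F)(F)F)cc3)CC2)cc1`, is the next one to be measured in this assay. It differs from compound 2 by hydrogen in place of methyl on an aromatic carbon. With both shown values sitting at the limit, there is no measured step to lean on. The expectation for this assay is no step beyond the scatter in either direction; the estimated step is a number no higher from compound 2 to compound 3 (the limit leaves the size open), expected to stay at or about the limit. Compound 3 is expected to give 100000 nM in this assay, with a range of 30000 nM to 300000 nM, and most likely only a limit will again be reported.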

Compound 3, half-maximal inhibitory concentration: > 100000 nM
Compound 3 ended at the assay's limit (the forecaster's own chance of this, stated with the estimate: 85%); the middle value lies on the limit itself.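

In this assay compound 3 gives > 100000 nM, a limit and not a number. Compound 2 also sits at a limit, so no step can be read between compound 2 and compound 3 for hydrogen in place of methyl on an aromatic carbon. The compounds shown leave open whether any structural change here alters the read-out, as every value stands at one limit: the limit of > 100000 nM in this assay, at which 3 of the 3 values shown sit.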